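Swapping Methyl for Chloro Across Two Cores

A few compounds are considered here, and "the series" means these few. Any claim that something is new, unique, unknown or untested is made for them only; others in the source may bear on it.

Compound 1, `Cc1ccc(-n2cc(C(=O)Nc3cc(F)cc(F)c3)c(=O)c3ccc(N(C)C)nc32)cc1OCCCCCCC[N+]12CCN(CC1)CC2`: 5.07%
Compound 2, `CN(C)c1ccc2c(=O)c(C(=O)Nc3cc(F)cc(F)c3)cn(-c3ccc(Cl)c(OCCCCCCC[N+]45CCN(CC4)CC5)c3)c2n1`: 8.08%
Compound 3, `Cc1cc(OCCCCCCC[n+]2ccccc2)ccc1-n1cc(C(=O)Nc2cc(F)cc(F)c2)c(=O)c2ccc(N(C)C)nc21`: "not active" (no number reported), no number

In an assay on LX2 cells for inhibition of COL1A1 promoter (Homo sapiens), read by a luciferase reporter, with a stated time of 24 h, tested at 20 uM (a lower number here means a weaker effect, a higher number a stronger effect of the compound at the concentration tested), compound 1 gives 5.07%. Compound 2 differs from it by chloro in place of methyl on an aromatic carbon, and in this assay compound 2 gives 8.08%, a step of a number 3 percentage points higher from compound 1 to compound 2 (within the scatter). Compound 3 is built on a different core; the difference between the two cores is not broken down here. In this assay compound 3 gives "not active" (no number reported), with no number given.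

Compound 4, `CN(C)c1ccc2c(=O)c(C(=O)Nc3cc(F)cc(F)c3)cn(-c3ccc(OCCCCCCC[n+]4ccccc4)cc3Cl)c2n1`, has not yet been measured. It differs from compound 3 by chloro in place of methyl on an aromatic carbon. This is the same kind of change as that from compound 1 to compound 2, but not the same: in compound 2 the chloro sits ortho to a large group and para to a large group, whereas in compound 4 it sits ortho to a large group and meta to a large group.

Compound 4 is expected to give about 4% in this assay, most likely between -6% and 13%. This expectation rests on the step of a number 3 percentage points higher from compound 1 to compound 2 (within the scatter), which stayed within the scatter, and on compound 3 having been reported as not active.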

Compound 4, a percentage reported as inhibition, at one concentration (the size of the read-out at that concentration, not a potency): "not active" (no number reported)
The entry for compound 4 holds no number, and the estimate cannot be compared.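

Going by these compounds alone, compound 3 and compound 4 offer no number to compare: in this assay compound 3 gives "not active" (no number reported) and compound 4 gives "not active" (no number reported) and so no step between them can be read. The compounds shown leave open whether chloro in place of methyl changes anything on this core. Nothing shown here offers an explanation for these results.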